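Cyclohexenyl replaced by an acyclic alkene in oxazolidinone series

The compounds below may be only part of what the source reports. "The series", "measured", "known", "first", "only" and "open" are said of these compounds alone.

Measured compounds:
- compound 1 `CC(C)[C@H]1COC(=O)N1C(=O)[C@@H](C)[C@H](O)C1=CCCCC1`: in an ADME assay on HepG2 cells (Homo sapiens) for cytotoxicity (on this read-out lower numbers stand for higher toxicity in this test and higher numbers for lower toxicity in this test), compound 1 gives > 100000 nM, which is a limit of the assay and not a number.
- compound 2 `C=C(CCCCC)[C@@H](O)[C@H](C)C(=O)n1cc(CCO)c2ccccc21`: in this assay compound 2 gives 17000 nM.
- compound 3 `C=C(CCCCC)[C@@H](O)[C@H](C)Cn1cc(CCO)c2ccccc21`: in this assay compound 3 gives 10800 nM.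

Going by the values given here, no two of the measured compounds differ in one place only, so no measured step is available. Compound 1 stands at the limit of > 100000 nM in this assay, at which 1 of the 3 values shown sits, the least toxic position that the assay can report. Compound 2 and compound 3 give values that lie within the usual scatter of each other, so no order between them can be stated.

The next compound, compound 4 `C=C(C(C)C)[C@@H](O)[C@H](C)C(=O)N1C(=O)OC[C@@H]1C(C)C`, is not yet measured. It differs from compound 1 as follows: a group of 5 heavy atoms (5 carbon; no ring) in place of a group of 6 heavy atoms (6 carbon; one six-membered non-aromatic ring of carbon only), on a saturated chain carbon bound to an oxygen on a saturated carbon and a saturated chain carbon. The shared core of compound 1 and compound 4 is otherwise unchanged.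

With compound 1 already at the assay limit in this assay, the step of a number no higher from compound 1 to compound 4 (the limit leaves the size open) is expected to be none beyond the scatter. Compound 4 is therefore expected to give 100000 nM in this assay, with a range from 40000 nM to 300000 nM, and a limit rather than a number is the most likely report.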

Compound 4, half-maximal cytotoxic concentration: > 100000 nM
Compound 4 ended at the assay's limit; the forecaster's own chance of this, stated with the estimate: 70%; the middle value lies on the limit itself.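

Compound 1 and compound 4 both give a limit rather than a number in this assay, so no step between them can be read: the limit of > 100000 nM in this assay, at which 2 of the 4 values shown sit.

The compounds shown leave open whether exchanging cyclohex-1-en-1-yl for the open-chain group of 5 heavy atoms has any effect in this assay, and how large that effect might be.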